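Methoxy Added to the Anilide Ring of Compound 2

The compounds below may be only part of what the source reports. "The series", "measured", "known", "first", "only" and "open" are said of these compounds alone.

The study covers two measured compounds and one that awaits measurement. Compound 1 `c1ccc(Cn2cnc3c(-c4ccco4)nccc32)cc1` was tested in an ADME assay on HepG2 cells (Homo sapiens) for cytotoxicity, read by trypan blue exclusion, with a stated time of 48 h, in the presence of a further agent that is not named here; a higher number here means that more compound is tolerated, a lower number that less compound is tolerated. For compound 1 the result is a limit of the assay, > 25000 nM, and not a number. Among the compounds with values here, compound 2 `COc1ccc2nc(C)cc(OCC(=O)Nc3ccccc3)c2c1` is the only compound with a full number, giving 118000 nM in this assay; the other result sits at the limit of > 25000 nM in this assay, at which 1 of the 2 values shown sits. Within the data shown here, the two compounds share no common scaffold, so no single-point step between them can be drawn, and their two values show only that both are tolerated at high concentration.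

Compound 3 `COc1cccc(NC(=O)COc2cc(C)nc3ccc(OC)cc23)c1` is the unmeasured compound. It differs from compound 2 in one place: methoxy in place of hydrogen on an aromatic carbon. Among the measured compounds shown here, no step between measured compounds shows what this change does, so the expectation rests on compound 2 alone. A step from compound 2 to compound 3 of a 1.2-fold lower number from compound 2 to compound 3 (0.07 log units; within the scatter) is expected, that is, no shift beyond the scatter of repeated measurements in this assay. Compound 3 is therefore estimated at 100000 nM, within a range from 40000 nM to 250000 nM.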

Compound 3, half-maximal cytotoxic concentration: 24700 nM
Compound 3: the middle estimate sits 4.0-fold (0.61 log units) above what was measured; measured number below the stated range.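

In this assay, within the data shown here, the change from phenyl to 3-methoxyphenyl provides the first step between two measured compounds that differ in one place: methoxy in place of hydrogen on an aromatic carbon, meta to a large group, gives a 4.8-fold lower number from compound 2 to compound 3 (0.68 log units; beyond the scatter). This position on the six-membered aromatic ring of carbon only therefore responds to substitution, with less compound tolerated once the methoxy enters, although the step is modest in size and compound 3 is still tolerated at a high concentration. Compound 1 has a different core and cannot be set against this step, and its result is a limit of the assay and not a number: the limit of > 25000 nM in this assay, at which 1 of the 3 values shown sits.

A single step cannot show whether the lower number belongs to methoxy itself or to any group at this position, and a hydroxyl, a fluorine, an amine or a longer chain such as ethoxy could each answer differently. It also leaves open whether methoxy on another carbon of the same ring would give a step of similar size.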